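Chloro in place of hydrogen, a step expected to stay small

The compounds below may be only part of what the source reports. "The series", "measured", "known", "first", "only" and "open" are said of these compounds alone.

Of the compounds shown here, two have been measured so far. Compound 1, `COc1cc(OC)c(C(=O)/C=C/c2ccccc2SC)c(OC)c1`, gives 0.5% in a functional assay on HCT-116 cells (Homo sapiens), read by fluorescence and BrdU incorporation, with a stated time of 48 h, tested at 25 uM; on this read-out higher numbers stand for a weaker effect at the one concentration tested and lower numbers for a stronger effect. Compound 2, `COc1cc(OC)c(C(=O)/C=C/c2ccccc2)c(OC)c1`, gives 2.6% in this assay. Among the measured compounds shown here, these two numbers lie within the usual scatter of each other, so neither can be called the stronger; the one measured step, a number 2.1 percentage points higher from compound 1 to compound 2 (within the scatter), comes from hydrogen in place of methylsulfanyl on an aromatic carbon. Compound 3, `COc1cc(OC)c(C(=O)/C=C/c2ccc(Cl)cc2)c(OC)c1`, is not yet measured. It differs from compound 2 by chloro in place of hydrogen on an aromatic carbon. For the measured compounds named here, no measured step involves a chloro group or this place on the ring, so the single step between compound 1 and compound 2 bears on it only as a sign that a small change on this ring left the read-out where it was. Both measured numbers also sit close to the low end of the scale, so the only room for a large move is toward a weaker effect. The expectation for compound 3 is a step of a number 0.4 percentage points higher from compound 2 to compound 3 (within the scatter), not beyond the scatter. The estimate for compound 3 in this assay is 3%, with a range from 0.5% to 15%.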

Compound 3, a percentage reported as activity, at one concentration (the size of the read-out at that concentration, not a potency): 0%
Compound 3: the middle estimate sits 3 percentage points above what was measured; measured number outside the range, below it.
By their numbers in this assay, from the lowest: compounds 3, 1 and 2 (each within the scatter of the next).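

Chloro in place of hydrogen gives a number 2.6 percentage points lower from compound 2 to compound 3 (within the scatter) in this assay, so this is the first reading at this place, on an aromatic carbon para to a large group, and the change from phenyl to 4-chlorophenyl leaves the read-out where it was. Exchanging the whole ring group, 4-chlorophenyl in place of 2-(methylsulfanyl)phenyl, gives a number 0.5 percentage points lower from compound 1 to compound 3 (within the scatter) and again moves nothing that can be told apart from scatter, so a substituent at either of these two ring places, or none at all, gives numbers that this single-concentration read-out cannot separate. No measurement at hand gives any reason for this flat result.

Still open, from the compounds shown here alone, is whether a group of a different kind at this same place, such as an amine or a carboxylic acid, would take the number beyond the scatter and show that the position matters at all. With only one concentration read, the three compounds also remain unranked by the strength of their effect at that concentration, and a series of lower concentrations would be needed to show whether chloro makes any difference.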